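The compounds below may be only part of what the source reports. "The series", "measured", "known", "first", "only" and "open" are said of these compounds alone.

Compound 1 `COc1cc(OC)cc(-c2ccc(-c3ccc(C(=N)N)c(F)c3)s2)c1` is the strongest of the three measured compounds in a functional assay on OVCAR-4 cells (Homo sapiens) for inhibition, read by sulforhodamine B assay, with a stated time of 48 h; on this read-out higher numbers stand for weaker inhibition of growth and lower numbers for stronger inhibition of growth: compound 1 gives 361 nM, while compound 3 `COc1ccc(-c2ccc(-c3ccc(C(=N)N)c(F)c3)s2)cc1` gives 6420 nM and compound 2 `N=C(N)c1ccc(-c2ccc(-c3ccccc3)s2)cc1F` gives 10400 nM, both gaps lying beyond the scatter. The one step recorded among these compounds, methoxy in place of hydrogen on an aromatic carbon, moved the number by a 1.6-fold lower number from compound 2 to compound 3 (0.21 log units; within the scatter).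

Compound 4 `COc1cc(OC)cc(-c2ccc(-c3ccc(C(=N)N)cc3)s2)c1` differs from compound 1 in one place: hydrogen in place of fluoro on an aromatic carbon. Within the data shown here, no measured pair shows this change, since the recorded step concerns a methoxy group and not the fluoro; the expectation for compound 4 therefore rests only on the standing of compound 1 itself. With nothing to point to a large shift in either direction, the number for compound 4 is expected to stay near that of compound 1, the estimated step being a 1.5-fold higher number from compound 1 to compound 4 (0.18 log units; within the scatter), with a slight lean toward a weaker result allowed for in the range. Compound 4 is thus estimated at 550 nM, between 150 nM and 2000 nM.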

Compound 4, concentration for 50% growth inhibition: 2060 nM
The estimate for compound 4 lay 3.7-fold (0.57 log units) below the measured number, outside the stated range (above it).
By their numbers in this assay, from the lowest: compound 1; then compound 4; then compounds 3 and 2 (each within the scatter of the next).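

In this assay, among these compounds, the change of hydrogen in place of fluoro, on an aromatic carbon ortho to a group of 3 heavy atoms and meta to a large group, gives a 5.7-fold higher number from compound 1 to compound 4 (0.76 log units; beyond the scatter) and is the first change at this place to be measured. Among the compounds shown here, the loss of this one heavy atom therefore weakens growth inhibition in this pair, whereas the only earlier step, a 1.6-fold lower number from compound 2 to compound 3 (0.21 log units; within the scatter) in the same assay, concerned a methoxy group elsewhere and stayed within the scatter. Nothing shown here explains why the fluoro matters in this pair.

As far as these compounds go, the change is read on the core of compound 1 alone, so it remains open whether it would carry over to compound 2 or compound 3. From the compounds shown here alone, it is also open how a chloro or a methyl group at this place would compare with the fluoro.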